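Changing the Amide Aryl Group: Compound 1 to Compound 3

The source may report more compounds than this note shows. Statements on the series, on what has been measured and on what is new or still open speak of the compounds shown alone.

Compound 1 `CN1C[C@H](C(=O)Nc2ccc(C3CC3)cc2)[C@@H](c2ccc(/C=C/C(=O)Nc3ccccc3N)cc2)C1`: 60 mL/min/kg in an in vitro ADME assay on microsomes from liver (Mus musculus) for pharmacokinetics, read by LC-MS, with a stated time of 10 min, tested at 1 uM; a higher number here means faster removal of the compound, a lower number slower removal
Compound 2 `CN1C[C@H](C(=O)Nc2ccc(F)cc2F)[C@@H](c2ccc(/C=C/C(=O)Nc3ccccc3N)cc2)C1`: 27 mL/min/kg in this assay

Compound 1 stands at the highest of the two numbers in this assay; its nearest neighbour is compound 2, reached by a 2.2-fold lower number from compound 1 to compound 2 (0.35 log units; beyond the scatter). Compound 3 `CN1C[C@H](C(=O)Nc2cccnc2)[C@@H](c2ccc(/C=C/C(=O)Nc3ccccc3N)cc2)C1` has not yet been measured. It differs from compound 1 in one place: pyridin-3-yl in place of 4-cyclopropylphenyl on an amide-type nitrogen. Among the measured compounds shown here, the one measured step that bears on this change is the exchange of the same 4-cyclopropylphenyl group on the same amide-type nitrogen, a 2.2-fold lower number from compound 1 to compound 2 (0.35 log units; beyond the scatter), a modest fall. Exchanging 4-cyclopropylphenyl for pyridin-3-yl is therefore expected to give a step of similar size in the same direction, toward a lower number, though with a single precedent the expected range must be wide. Compound 3 is therefore estimated at 28 mL/min/kg, with a range from 12 mL/min/kg to 60 mL/min/kg. This amounts to an expected step of a 2.1-fold lower number from compound 1 to compound 3 (0.33 log units; beyond the scatter).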

Compound 3, clearance: 41 mL/min/kg
Estimate against measurement, compound 3: 1.5-fold (0.17 log units) below; low and high end bracket the measured number.
By their numbers in this assay, from the lowest: compounds 2, 3 and 1 (each within the scatter of the next, the first and the last beyond it).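

In this assay pyridin-3-yl in place of 4-cyclopropylphenyl on the amide-type nitrogen gives a 1.5-fold lower number from compound 1 to compound 3 (0.17 log units; within the scatter) and so cannot be told apart from no change, which the earlier exchange to 2,4-difluorophenyl did not show. Set against 2,4-difluorophenyl, pyridin-3-yl gives a 1.5-fold higher number from compound 2 to compound 3 (0.18 log units; within the scatter) and cannot be separated from that group either, so the only step beyond the scatter at this position remains a 2.2-fold lower number from compound 1 to compound 2 (0.35 log units; beyond the scatter) and the three groups do not fall into a clear order. Nothing measured here accounts for these numbers.

The compounds shown leave open how an unsubstituted phenyl, a pyridin-4-yl or a saturated piperidin-4-yl would read on this nitrogen. They also leave open whether the loss of the cyclopropyl ring or the entry of the ring nitrogen weighs more in this exchange.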